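This account rests on a few compounds, and the source may have more. Where it says the series, first, only, none or still open, it means among the compounds named here.

Of the compounds shown here, three have been measured so far, all built on one shared core and differing in the group attached to a nitrogen on an aromatic ring. Compound 3 `Cn1c(=O)c(S(=O)(=O)c2ccc(F)cc2F)cc2cnc(Nc3ccncn3)nc21` is one of them. In a functional assay on K562 cells (Homo sapiens) for inhibition, read by trypan blue exclusion, with a stated time of 72 h (on this read-out higher numbers stand for weaker inhibition and lower numbers for stronger inhibition), compound 3 gives 30000 nM, the second highest of the three numbers. Among the measured compounds shown here, compound 1 `Cn1c(=O)c(S(=O)(=O)c2ccc(F)cc2F)cc2cnc(Nc3ccc4[nH]ncc4c3)nc21` gives 50000 nM in this assay, and the one measured single step, a 1.7-fold lower number from compound 1 to compound 3 (0.22 log units; within the scatter), lies within the scatter, so the two cannot be ranked. Compound 2 `Cc1ccc(S(=O)(=O)c2cc3cnc(Nc4cnc5[nH]ccc5c4)nc3n(C)c2=O)cc1` gives 15000 nM in this assay, a value also within the scatter of compound 3.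

Compound 4 `Cn1c(=O)c(S(=O)(=O)c2ccc(F)cc2F)cc2cnc(Nc3cnc4[nH]ccc4c3)nc21` is not yet measured. It differs from compound 3 in one place: a group of 9 heavy atoms (7 carbon, 2 nitrogen; one five-membered aromatic ring with 1 hetero atom, one six-membered aromatic ring with 1 hetero atom) in place of a group of 6 heavy atoms (4 carbon, 2 nitrogen; one six-membered aromatic ring with 2 hetero atoms), on a nitrogen on an aromatic ring. For the measured compounds named here, the entering group is the one that compound 2 carries, but compound 2 also differs in its sulfonyl-linked group, so no single step isolates this change. Going by the values given here, the only single step measured swapped one ring system for another on the same nitrogen and stayed within the scatter, so no step beyond the scatter is expected in this assay for compound 4. Compound 4 is estimated at 25000 nM, with a range from 8000 nM to 80000 nM. The estimated step is a 1.2-fold lower number from compound 3 to compound 4 (0.08 log units; within the scatter), expected to stay within the scatter.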

Compound 4, half-maximal inhibitory concentration: 750 nM
The estimate for compound 4 lay 33-fold (1.52 log units) above the measured number, and the stated range ends above it.
By their numbers in this assay, from the lowest: compound 4; then compounds 2, 3 and 1 (each within the scatter of the next, the first and the last beyond it).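

In this assay, among the compounds shown here, the group on this nitrogen turns out to matter a great deal: replacing pyrimidin-4-yl with the two-ring group gives a 40-fold lower number from compound 3 to compound 4 (1.60 log units; beyond the scatter), although the only earlier single step at this place stayed within the scatter. Size alone does not separate the groups, since 1H-indazol-5-yl has the same heavy-atom count as the entering group, yet the change gives a 67-fold lower number from compound 1 to compound 4 (1.82 log units; beyond the scatter), so the arrangement of atoms in the two rings counts. The entering group is not enough by itself either, as 2,4-difluorophenyl in place of 4-methylphenyl on the sulfonyl sulfur gives a 20-fold lower number from compound 2 to compound 4 (1.30 log units; beyond the scatter).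

Nothing shown explains why these steps are so large. Also open, as far as these compounds go, is whether a morpholine or a simple amine on this nitrogen would keep the low number of compound 4.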